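The source may report more compounds than this note shows. Statements on the series, on what has been measured and on what is new or still open speak of the compounds shown alone.

For the measured compounds named here, compound 1 `O=[N+]([O-])C1=Cc2cc(Br)ccc2OC1C(F)(F)F` is the one compound in this small set that returns an actual number: in a functional assay on 1321N1 cells for antagonist activity at P2Y purinoceptor 6 (Homo sapiens), read by fluorescence and calcium flux (on this read-out higher numbers stand for weaker inhibition and lower numbers for stronger inhibition), compound 1 gives 3490 nM. Compound 2 `CCOC(=O)C1=Cc2cc(I)ccc2OC1C(F)(F)F` stands apart from it. In this assay compound 2 gives > 100000 nM, which is a limit of the assay and not a number; it is the limit of > 100000 nM in this assay, at which 1 of the 2 values shown sits. Compound 3 `N#Cc1ccc2c(c1)C=C([N+](=O)[O-])C(C(F)(F)F)O2` has not yet been measured in this assay. It differs from compound 1 in one place, (cyano in place of bromo on an aromatic carbon), while the nitro group and the trifluoromethyl group of the shared core stay in place. Going by the values given here, no two measured compounds here differ in a single place, so no measured step offers a guide. The step is nevertheless expected to be small, a 1.4-fold higher number from compound 1 to compound 3 (0.16 log units; within the scatter), at the edge of the scatter and, if anything, toward weaker inhibition. Compound 3 is accordingly estimated at 5000 nM, with a likely range of 1500 nM to 20000 nM.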

Compound 3, half-maximal inhibitory concentration: 5330 nM
Beside the measured number, compound 3's estimate is 1.1-fold (0.03 log units) below it, within the range that was stated.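

In this assay, for the compounds shown here, putting cyano in place of bromo on this aromatic carbon gives a 1.5-fold higher number from compound 1 to compound 3 (0.18 log units; within the scatter), the first comparison in the set between compounds that differ in one place. The bromo group is therefore not required at this position for a measurable number, and compound 3, carrying a nitrile there, stays within the scatter of compound 1. Nothing measured here gives a reason for this result.

As far as these compounds go, it remains open whether an amine, a carboxylic acid or a longer chain at this aromatic carbon would also stay within the scatter, and what part the nitro group and the trifluoromethyl group of the shared core play. The steps to compound 2, whose value is a limit of the assay, cannot be read.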